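Methyl in Place of Nitro: Expectation for Compound 4

A few compounds are considered here, and "the series" means these few. Any claim that something is new, unique, unknown or untested is made for them only; others in the source may bear on it.

Measured so far in an assay for inhibition of epoxide hydrolase 1 (Homo sapiens), read by fluorescence, using microsomes; a higher number here means a weaker inhibitor, a lower number a stronger inhibitor:
compound 1 `COc1cc([N+](=O)[O-])ccc1NC(=S)NC(C)=O` gives 1870 nM
compound 2 `CC(=O)NC(=S)Nc1ccc(Oc2ccccc2)cc1` gives 3700 nM
compound 3 `COc1cc([N+](=O)[O-])ccc1NC(=S)NC(=O)c1ccccc1` gives 1650 nM

Among these three numbers, compound 1 stands second highest. Within the data shown here, the only step between measured compounds that differ in a single place is a 1.1-fold lower number from compound 1 to compound 3 (0.05 log units; within the scatter), phenyl in place of methyl on a carbonyl carbon. Compound 2 differs from compound 1 in more than one place, and its number lies within the scatter of that of compound 1, so the three measured values sit close together.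

Compound 4 `COc1cc(C)ccc1NC(=S)NC(C)=O` keeps the core of compound 1 and differs from it only at one ring position: methyl in place of nitro on an aromatic carbon. Among the measured compounds shown here, no measured step bears on this change; the one step that has been measured concerns a different part of the molecule and was itself within the scatter. With no evidence for movement in either direction, the expected step is a 1.3-fold higher number from compound 1 to compound 4 (0.13 log units; within the scatter), that is, nothing beyond the scatter. Compound 4 is therefore estimated at 2500 nM, with a range from 800 nM to 8000 nM.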

Compound 4, half-maximal inhibitory concentration: 1690 nM
Estimate against measurement, compound 4: 1.5-fold (0.17 log units) above, within the range that was stated.
By their numbers in this assay, from the lowest: compounds 3, 4, 1 and 2 (each within the scatter of the next, the first and the last beyond it).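

In this assay, the change of nitro to methyl gives a 1.1-fold lower number from compound 1 to compound 4 (0.04 log units; within the scatter), so this ring position now has a reading of its own. Among these compounds, the one earlier single-place step concerned a group on the carbonyl carbon, whereas this one shows that, on the aromatic carbon para to the group of 7 heavy atoms, a nitro with 3 heavy atoms and 2 hydrogen-bond acceptors can give way to a methyl with 1 heavy atom and no acceptors, without a step beyond the scatter. No available measurement explains why these two groups read alike.

The compounds shown leave open whether an amine, a carboxylic acid or a longer chain at this position would also stay within the scatter. They also leave open whether methyl in place of nitro would give a similar step on compound 3, which carries phenyl on the carbonyl carbon.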